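A fluorophenyl isoxazole and one more chain carbon

The source may report more compounds than this note shows. Statements on the series, on what has been measured and on what is new or still open speak of the compounds shown alone.

Measured so far:
Compound 1, `CCCCc1cc2ccccc2nc1-c1cc(-c2ccccc2)no1`: > 100000 nM
Compound 2, `CCCc1cc2ccccc2nc1-c1cc(-c2ccc(F)cc2)no1`: 48400 nM

Among the compounds with values here, in a functional assay on MDA-MB-231 cells (Homo sapiens) for inhibition, read by MTT assay, with a stated time of 24 h (a higher number here means a weaker inhibitor, a lower number a stronger inhibitor), compound 2 gives 48400 nM, the only actual number among the two values shown. For compound 1 the result in this assay is a limit, > 100000 nM, not a number; it sits at the limit of > 100000 nM in this assay, at which 1 of the 2 values shown sits. Within the data shown here, compound 1 and compound 2 differ in two places, so the two values say only that compound 2 returned a number while compound 1 did not.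

The next compound, compound 3, `CCCCc1cc2ccccc2nc1-c1cc(-c2ccc(F)cc2)no1`, keeps the fluorophenyl-bearing core of compound 2 and changes only the chain: methyl in place of hydrogen on a saturated chain carbon, three bonds along the chain from an aromatic carbon. Among the measured compounds shown here, no step between measured compounds reports what such a chain extension does in this assay, so the account has no measured yardstick for it.

Compound 3 is therefore expected to stay in the weak range of compound 2, with a step of a 1.2-fold higher number from compound 2 to compound 3 (0.09 log units; within the scatter) that may not exceed the usual scatter. The estimate for compound 3 in this assay is 60000 nM, in a range from 25000 nM to 150000 nM.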

Compound 3, half-maximal inhibitory concentration: 24200 nM
For compound 3 the middle estimate is 2.5-fold (0.39 log units) above the measured one; the measured number lies below the stated range.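

In this assay, methyl in place of hydrogen on a saturated chain carbon, three bonds along the chain from an aromatic carbon, now has a measured step: a 2.0-fold lower number from compound 2 to compound 3 (0.30 log units; within the scatter), so with the fluorophenyl part held fixed, the propyl and butyl chains cannot be told apart here. Fluoro in place of hydrogen on an aromatic carbon, with the butyl chain held fixed, gives an at least 4.1-fold lower number from compound 1 to compound 3 (0.61 log units; beyond the scatter), the first comparison in this series that changes one place only and lies beyond the scatter. Compound 1 gives a limit and not a number, so the size of that step is known only as a floor: the limit of > 100000 nM in this assay, at which 1 of the 3 values shown sits.

The compounds shown leave open whether a longer chain, or a chain ending in an amine or a carboxylic acid, would move the number beyond the scatter, and whether chloro or methoxy in place of the fluoro would give a step like the one seen for fluoro. From the compounds shown here alone, every value here comes from this assay, so whether the fluoro step also holds with the propyl chain, or in other cells, remains open.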